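The source may hold more compounds than are shown below. What is called first, only, known or untested is meant among the compounds shown, and "the series" means these compounds.

The study measured metabolic stability in an ADME assay on microsomes from liver (Macaca mulatta) for metabolic stability, with a stated time of 0.5 h, tested at 0.5 mg/mL; on this read-out higher numbers stand for a more stable compound and lower numbers for a less stable compound. For the measured compounds named here, compound 1 `CN(C)C(=O)CCNC(=O)c1cc(-c2ccccc2)no1` is the less stable of the two compounds measured so far: in this assay compound 1 gives 4.7%, the lowest number recorded, while compound 2 `CN(C)C(=O)CCN1CCc2c(cc(-c3ccc(F)cc3)n2C)C1=O`, built on a different core, reaches 42% in this assay, a much higher figure. Compound 3 `CC(=O)N1CC(CNC(=O)c2cc(-c3ccccc3)no2)C1` keeps the core of compound 1 and differs from it in one place: 1-acetylazetidin-3-yl in place of (dimethylcarbamoyl)methyl on a saturated chain carbon bound to an amide-type nitrogen. Going by the values given here, no measured pair in this set shows what such a change does on this core, so the expectation for compound 3 rests only on the low number of compound 1. A modest gain in stability is expected, giving an estimated step of a number 10.3 percentage points higher from compound 1 to compound 3 (beyond the scatter) from compound 1 to compound 3. Compound 3 is therefore expected to show about 15% in this assay, within a range of 3% to 40%.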

Compound 3, percent of the compound remaining: 17%
Compound 3: middle estimate off by 2 percentage points, on the low side; measured number inside the range.
By their numbers in this assay, from the lowest: compound 1; then compound 3; then compound 2.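

For the compounds shown here, for the first time, a change at the saturated chain carbon bound to an amide-type nitrogen can be read on the core of compound 1. In this assay, replacing (dimethylcarbamoyl)methyl with 1-acetylazetidin-3-yl gives a number 12.3 percentage points higher from compound 1 to compound 3 (beyond the scatter), so the read-out at this place responds to the group it carries. The change adds a four-membered non-aromatic ring while the counts of hydrogen-bond donors and acceptors stay the same, and nothing available accounts for the step.

From the compounds shown here alone, it remains open whether the step belongs to the ring or to the acetyl group, and what a free azetidine amine, a carboxylic acid or a longer chain would give at this place. This single pair also leaves open whether the same change would give a similar step on another core.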